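Adding a Methyl to the But-1-en-1-yl Chain

The source may hold more compounds than are shown below. What is called first, only, known or untested is meant among the compounds shown, and "the series" means these compounds.

Compound 3 `CC/C=C/C(=O)Nc1cc2c(N3CCc4ccccc43)ncnc2cc1OC` was tested in a functional assay on PC-3 cells (Homo sapiens) for antiproliferative activity, read by MTT assay, with a stated time of 72 h (on this read-out higher numbers stand for weaker inhibition and lower numbers for stronger inhibition), where compound 3 gives 5890 nM. Among the three measured values it stands second highest, with compound 1 `C=CC(=O)Nc1cc2c(N3CCc4ccccc43)ncnc2cc1OC` nearest: in this assay compound 1 gives 5940 nM. Compound 2 `C=C(C)C(=O)Nc1cc2c(N3CCc4ccccc43)ncnc2cc1OC` lies furthest away, and in this assay compound 2 gives 4830 nM. The steps that connect these three are all small: a 1.2-fold lower number from compound 1 to compound 2 (0.09 log units; within the scatter), a 1.0-fold lower number from compound 1 to compound 3 (0.00 log units; within the scatter) and a 1.2-fold higher number from compound 2 to compound 3 (0.09 log units; within the scatter), each within the scatter, so the three compounds cannot be ranked against one another on these numbers.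

Compound 4 `COc1cc2ncnc(N3CCc4ccccc43)c2cc1NC(=O)/C=C/C(C)C` differs from compound 3 by methyl in place of hydrogen on a saturated chain carbon bound to a double-bonded chain carbon and a saturated chain carbon. Among the measured compounds shown here, the steps that bear on this change are those in which the chain on the carbonyl carbon was altered without touching the rest of the molecule, namely a 1.0-fold lower number from compound 1 to compound 3 (0.00 log units; within the scatter) and a 1.2-fold higher number from compound 2 to compound 3 (0.09 log units; within the scatter), both within the scatter. Because the earlier change from compound 1 to compound 3 gave a 1.0-fold lower number from compound 1 to compound 3 (0.00 log units; within the scatter), no step beyond the scatter is expected for the further branching of the chain, and the step from compound 3 to compound 4 is estimated as a 1.0-fold higher number from compound 3 to compound 4 (0.00 log units; within the scatter). For compound 4 the expected value in this assay is therefore 5900 nM, with a range from 3000 nM to 12000 nM.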

Compound 4, half-maximal inhibitory concentration: 6530 nM
For compound 4 the middle estimate is 1.1-fold (0.04 log units) below the measured one; the range from low to high includes it.
By their numbers in this assay, from the lowest: compounds 2, 3, 1 and 4 (each within the scatter of the next).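

Methyl in place of hydrogen on a saturated chain carbon bound to a double-bonded chain carbon and a saturated chain carbon, which turns but-1-en-1-yl into 3-methylbut-1-en-1-yl, gives a 1.1-fold higher number from compound 3 to compound 4 (0.04 log units; within the scatter) in this assay and so extends the earlier picture to a branched chain: this added carbon produces no step that can be read beyond the scatter. The same holds against the two shorter chains, with a 1.1-fold higher number from compound 1 to compound 4 (0.04 log units; within the scatter) and a 1.4-fold higher number from compound 2 to compound 4 (0.13 log units; within the scatter) as well, so vinyl, 1-methylethenyl, but-1-en-1-yl and 3-methylbut-1-en-1-yl on the carbonyl carbon cannot be told apart on this read-out. Nothing measured alongside these values speaks to why the chain makes so little difference here.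

From the compounds shown here alone, all four compounds carry a double-bonded chain on the carbonyl carbon and the same core, so it remains open whether an amine such as dimethylamino at the end of the chain, a longer chain or a fully saturated chain would move the number beyond the scatter. Going by these compounds, it also remains open whether a change elsewhere on the core, for instance replacing the methoxy group, would do so.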